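This account rests on a few compounds, and the source may have more. Where it says the series, first, only, none or still open, it means among the compounds named here.

Within the data shown here, in an in vitro functional assay on cells for agonist activity at Bombesin receptor subtype-3 (Homo sapiens), read by luminescence and calcium flux (a lower number here means that less compound is needed, a higher number that more compound is needed for the effect), compound 3 `N#Cc1ccccc1Cc1cnc(CCc2ccc(-c3ccccc3C(=O)O)cc2)[nH]1` gives 5480 nM, the highest of the three numbers measured so far. Compound 1 `O=C(O)c1ccccc1-c1ccc(CCc2ncc(-c3ccccc3)[nH]2)cc1` gives 4950 nM, and a 1.1-fold higher number from compound 1 to compound 3 (0.04 log units; within the scatter). Compound 2 `CCCCc1cnc(CCc2ccc(-c3ccccc3C(=O)O)cc2)[nH]1` gives 2710 nM, and a 2.0-fold higher number from compound 2 to compound 3 (0.31 log units; beyond the scatter). Compound 4 `COc1cccc(Cc2cnc(CCc3ccc(-c4ccccc4C(=O)O)cc3)[nH]2)c1` differs from compound 3 in one place: 3-methoxyphenyl in place of 2-cyanophenyl on a saturated chain carbon bound to an aromatic carbon. The two steps already seen in this part of the structure are the closest guides, namely a 2.0-fold higher number from compound 2 to compound 3 (0.31 log units; beyond the scatter) and a 1.1-fold higher number from compound 1 to compound 3 (0.04 log units; within the scatter); both are small, so exchanging one substituted phenyl for another is expected to move the number little, if at all, beyond the scatter. For compound 4 in this assay an estimated 4500 nM is expected, between 1800 nM and 11000 nM, which means a 1.2-fold lower number from compound 3 to compound 4 (0.09 log units; within the scatter) is expected.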

Compound 4, half-maximal effective concentration: 4120 nM
Beside the measured number, compound 4's estimate is 1.1-fold (0.04 log units) above it; the range from low to high includes it.
By their numbers in this assay, from the lowest: compounds 2, 4, 1 and 3 (each within the scatter of the next, the first and the last beyond it).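

In this assay, a nitrile on the benzyl ring and a methoxy group on it read alike at this place, with a 1.3-fold lower number from compound 3 to compound 4 (0.12 log units; within the scatter). The 3-methoxybenzyl group also stays within the scatter of the other groups, with a 1.5-fold higher number from compound 2 to compound 4 (0.18 log units; within the scatter) and a 1.2-fold lower number from compound 1 to compound 4 (0.08 log units; within the scatter), so the small gap beyond the scatter seen between the butyl and 2-cyanobenzyl compounds does not recur here. No outside evidence bears on this result. Going by these compounds, whether an amine or a longer chain at this place would move the number well beyond the scatter remains open.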